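Replacing a Chloro with a Hydroxymethyl-Bearing Branched Group

The source may report more compounds than this note shows. Statements on the series, on what has been measured and on what is new or still open speak of the compounds shown alone.

Compound 1 `Cc1ccc(NC(=O)Nc2cc(-c3ccc(Cl)c(C(=O)O)c3)ccc2Oc2ccccc2C(C)(C)C)cc1`: 2400 nM
Compound 2 `CCc1ccccc1Oc1ccc(-c2ccc(OC)c(C(=O)O)c2)cc1NC(=O)Nc1ccc(C)cc1`: 540 nM
Compound 3 `COc1ccc(-c2ccc(Oc3ccccc3Cl)c(NC(=O)Nc3ccc(C)cc3)c2)cc1C(=O)O`: 830 nM

In an assay on HeLa cells for inhibition of Indoleamine 2,3-dioxygenase 1 (Homo sapiens), with a stated time of 20 h (a higher number here means a weaker inhibitor, a lower number a stronger inhibitor), compound 3 stands second highest of the three numbers. Its nearest neighbour is compound 2, which lies within the scatter of it; the furthest is compound 1, which lies beyond the scatter. Compound 4 `COc1ccc(-c2ccc(Oc3ccccc3C(C)(C)CO)c(NC(=O)Nc3ccc(C)cc3)c2)cc1C(=O)O` differs from compound 3 in one place: 1-(hydroxymethyl)-1-methylethyl in place of chloro on an aromatic carbon. For the measured compounds named here, the only measured step at that position, a 1.5-fold higher number from compound 2 to compound 3 (0.19 log units; within the scatter), changed little. Compound 1 differs from compound 3 in more than one place, so it gives no clean comparison. The entering group is considerably larger and brings a hydroxyl, so some weakening is plausible but uncertain. Compound 4 is therefore expected to give about 1100 nM (range 400 nM to 3000 nM), an expected step of a 1.3-fold higher number from compound 3 to compound 4 (0.12 log units; within the scatter) that may not exceed the scatter.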

Compound 4, half-maximal inhibitory concentration: 2400 nM
Compound 4: middle estimate off by 2.2-fold (0.34 log units), on the low side; the measured number falls inside the stated range.
By their numbers in this assay, from the lowest: compounds 2 and 3 (each within the scatter of the next); then compounds 1 and 4 (each within the scatter of the next).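

In this assay, for the compounds shown here, this position proved sensitive for the first time: chloro and ethyl had stayed within the scatter of each other, whereas 1-(hydroxymethyl)-1-methylethyl gives a 2.9-fold higher number from compound 3 to compound 4 (0.46 log units; beyond the scatter) and a 4.4-fold higher number from compound 2 to compound 4 (0.65 log units; beyond the scatter) in this series. The ortho place on this ring therefore accepts some groups without a clear loss, but not all. Nothing available here explains the weakening.

Going by these compounds, whether it follows the branched carbons or the hydroxyl remains open. An aminomethyl or a methoxy group at this place could help separate the two.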